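This account rests on a few compounds, and the source may have more. Where it says the series, first, only, none or still open, it means among the compounds named here.

In a functional assay on HCT-116 cells (Homo sapiens), read by MTT assay, with a stated time of 3 days (on this read-out lower numbers stand for stronger inhibition and higher numbers for weaker inhibition), compound 1 `CN(C)c1ncnc2[nH]cc(Sc3cccs3)c12` gives 27500 nM, compound 2 `CNc1ncnc2[nH]cc(Sc3cccs3)c12` gives 45300 nM and compound 3 `c1coc(-c2ncnc3[nH]cc(Sc4cccs4)c23)c1` gives 19500 nM. Compound 2 thus holds the highest of the three numbers, but the two steps that reach it differ in standing: a 1.6-fold higher number from compound 1 to compound 2 (0.22 log units; within the scatter), while a 2.3-fold lower number from compound 2 to compound 3 (0.37 log units; beyond the scatter). Compound 4 `Cc1ncnc2[nH]cc(Sc3cccs3)c12` has not yet been measured. It differs from compound 2 at a single place, with methyl in place of methylamino on an aromatic carbon. Within the data shown here, no measured step makes this exact exchange. The closest evidence comes from the two steps that replace the group on that aromatic carbon, a 1.4-fold lower number from compound 1 to compound 3 (0.15 log units; within the scatter) and a 2.3-fold lower number from compound 2 to compound 3 (0.37 log units; beyond the scatter). Both lead to a lower number, and neither is large, so only a small change in this assay is expected, most likely towards a lower number. The expected step is a 1.5-fold lower number from compound 2 to compound 4 (0.18 log units; within the scatter). For compound 4 the estimate is 30000 nM, with an expected range from 15000 nM to 60000 nM.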

Compound 4, half-maximal inhibitory concentration: 29100 nM
Estimate against measurement, compound 4: 1.0-fold (0.01 log units) above, and the stated range covers the measured number.
By their numbers in this assay, from the lowest: compounds 3, 1, 4 and 2 (each within the scatter of the next, the first and the last beyond it).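

In this assay, a plain methyl on this aromatic carbon holds its place among the earlier groups: a 1.6-fold lower number from compound 2 to compound 4 (0.19 log units; within the scatter), a 1.1-fold higher number from compound 1 to compound 4 (0.02 log units; within the scatter) and a 1.5-fold higher number from compound 3 to compound 4 (0.17 log units; within the scatter). The earlier compounds shown here all carried a nitrogen group or furan-2-yl here, whereas compound 4 shows that a group with no hydrogen-bond donor or acceptor and no ring still stays within the scatter of all three, even though compound 2 and compound 3 lie beyond the scatter of each other. Nothing measured here explains these small steps. Going by these compounds, it remains open whether a primary amine, a carboxylic acid or a longer chain such as n-butyl at this position would move the number beyond the scatter of compound 4. The compounds shown also vary only this one place, so they leave open whether the same steps would hold on a different core.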